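Piperazine aryl variation on the sulfonamide series

The source may report more compounds than this note shows. Statements on the series, on what has been measured and on what is new or still open speak of the compounds shown alone.

Compound 3 `CCCn1c(=O)[nH]c2nc(-c3ccc(S(=O)(=O)N4CCN(c5ccccc5C)CC4)cc3)[nH]c2c1=O` gives 419 nM in an assay on CHO cells for displacement of a labelled ligand from adenosine receptor A1 (Homo sapiens), read by scintillation counting, with a stated time of 90 min, in the presence of a further agent that is not named here; on this read-out lower numbers stand for stronger inhibition and higher numbers for weaker inhibition. It holds the lowest of the two numbers in hand; compound 2 `CCCn1c(=O)[nH]c2nc(-c3ccc(S(=O)(=O)N4CCN(Cc5cccc(C)c5)CC4)cc3)[nH]c2c1=O` gives 795 nM, and the gap a 1.9-fold lower number from compound 2 to compound 3 (0.28 log units; within the scatter) is within the scatter. Compound 1 `CCCn1c(=O)[nH]c2nc(-c3ccc(S(=O)(=O)N4CCN(c5ccc(Cl)cc5F)CC4)cc3)[nH]c2c1=O` reaches only the limit > 1000 nM, which is not a number. Against that limit the step of an at least 2.3-fold lower number from compound 1 to compound 3 (0.37 log units; beyond the scatter) is at least modest, and an at least 1.2-fold lower number from compound 1 to compound 2 (0.09 log units; that floor lies within the scatter) reaches only a floor within the scatter.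

Compound 4 `CCCn1c(=O)[nH]c2nc(-c3ccc(S(=O)(=O)N4CCN(c5cccc(Cl)c5)CC4)cc3)[nH]c2c1=O` is the next variant: 3-chlorophenyl in place of 2-methylphenyl on an amine nitrogen in a ring. Going by the values given here, no measured step exchanges the two groups in question, so the expectation rests on the step from the halogen-bearing phenyl of compound 1 to the methylphenyl of compound 3, which was an at least 2.3-fold lower number from compound 1 to compound 3 (0.37 log units; beyond the scatter). Returning to a halogen on the phenyl is therefore expected to move the number back upward, by about a 1.8-fold higher number from compound 3 to compound 4 (0.25 log units; within the scatter), a step near the edge of the scatter. Compound 4 is expected to give 750 nM, with a range from 320 nM to 1800 nM.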

Compound 4, inhibition constant: > 1000 nM
Compound 4: a limit, no number; the forecaster's own chance of this, stated with the estimate: 25%; at least 1.3-fold (0.12 log units) between middle value and limit.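

In this assay compound 4 gives a limit and not a number, the second compound in the series to do so: the limit of > 1000 nM in this assay, at which 2 of the 4 values shown sit. The exchange on the amine nitrogen in a ring keeps the heavy-atom count and adds no hydrogen-bond donor or acceptor, yet it gives an at least 2.3-fold higher number from compound 3 to compound 4 (0.37 log units; beyond the scatter), so the position does respond to a change of this size, whereas an at least 1.2-fold higher number from compound 2 to compound 4 (0.09 log units; that floor lies within the scatter) reaches only a floor within the scatter. Among the compounds with a phenyl directly on this nitrogen, both halogen-bearing ones stop at the limit and only the 2-methylphenyl of compound 3 gives a number, and the step between the two limits cannot be read.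

Methyl and chlorine here differ both in identity and in their place on the phenyl, and the compounds shown do not separate the two. From the compounds shown here alone, how a methoxy group or a carboxylic acid on that phenyl would read remains open.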